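The source may report more compounds than this note shows. Statements on the series, on what has been measured and on what is new or still open speak of the compounds shown alone.

Of the compounds shown here, three have been measured in a functional assay on CCRF-CEM cells (Homo sapiens), read by MTT assay, with a stated time of 72 h (a higher number here means a weaker inhibitor, a lower number a stronger inhibitor), and every one of them gives only a limit. Compound 1 `Cc1nc(N)c2c(-c3ccco3)cn([C@@H]3O[C@H](CO)[C@@H](O)[C@H]3O)c2n1` gives > 100000 nM, which is a limit of the assay. Compound 2 `Cc1nc(N)c2c(-c3cc4ccccc4o3)cn([C@@H]3O[C@H](CO)[C@@H](O)[C@H]3O)c2n1` gives > 20000 nM, also a limit. Compound 3 `CNc1ncnc2c1c(-c1cc3ccccc3o1)cn2[C@@H]1O[C@H](CO)[C@@H](O)[C@H]1O` gives > 20000 nM, again a limit.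

Compound 1 and compound 2 differ by furan-2-yl in place of 1-benzofuran-2-yl on an aromatic carbon. The step that the two limits leave unreadable from compound 2 to compound 1 has no readable size, as the two values sit at the limit of > 100000 nM in this assay, at which 1 of the 3 values shown sits, and at the limit of > 20000 nM in this assay, at which 2 of the 3 values shown sit. Compound 3 shares its atoms with compound 2 but joins them differently; the difference between the two cores is not broken down here.

Compound 4 `CNc1ncnc2c1c(-c1ccco1)cn2[C@@H]1O[C@H](CO)[C@@H](O)[C@H]1O` has not been measured. It stands to compound 3 as compound 1 stands to compound 2: the change is furan-2-yl in place of 1-benzofuran-2-yl on an aromatic carbon, at a place described in the same words for both pairs, so it is the same change. The earlier step gave no readable size, so nothing can be carried over from it. Compound 4 is therefore expected to remain at a limit, with an estimated step that the limit leaves unreadable from compound 3 to compound 4 from compound 3. The estimate for compound 4 is 100000 nM, between 20000 nM and 500000 nM.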

Compound 4, half-maximal inhibitory concentration: 180 nM
The estimate for compound 4 lay 560-fold (2.74 log units) above the measured number, and the stated range ends above it.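

In this assay, furan-2-yl in place of 1-benzofuran-2-yl gives an at least 110-fold lower number from compound 3 to compound 4 (2.04 log units; beyond the scatter), so on this core the change goes with a large fall in the number. The true size of this step remains unknown, since compound 3 stands at a limit and not at a measured number: the limit of > 20000 nM in this assay, at which 2 of the 4 values shown sit. The same change on the core of compound 2 leads to compound 1, which also stands at a limit, so that step cannot be read, and the pair shows neither that the change carries over between the two cores nor that it fails to: the limit of > 100000 nM in this assay, at which 1 of the 4 values shown sits.

The compounds shown leave open whether compound 4 owes its number to furan-2-yl alone or to furan-2-yl together with its particular core. They also leave open how the number would move with another group on the same aromatic carbon, such as a thiophen-2-yl ring, a phenyl ring or an amine.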